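Swapping the cinnamoyl aryl ring in a chalcone series

The source may hold more compounds than are shown below. What is called first, only, known or untested is meant among the compounds shown, and "the series" means these compounds.

Of the compounds shown here, three that share one core have been tested in a functional assay on OVCAR-5 cells (Homo sapiens) for inhibition; on this read-out lower numbers stand for stronger inhibition of growth and higher numbers for weaker inhibition of growth. Within the data shown here, compound 1 `COc1cc(/C=C/C(=O)c2cccc(-n3cc(-c4ccc(Cl)cc4)[nH]c3=O)c2)cc(OC)c1OC` gives 3110 nM, and compound 2 `COc1cc(/C=C/C(=O)c2cccc(-n3cc(-c4ccccc4)[nH]c3=O)c2)cc(OC)c1OC` gives 1880 nM; the step of a 1.7-fold lower number from compound 1 to compound 2 (0.22 log units; within the scatter) is the only measured step that changes a single group. Compound 3 `COc1ccc(-c2cn(-c3cccc(C(=O)/C=C/c4ccc(O)c(OC)c4)c3)c(=O)[nH]2)cc1` gives 3380 nM, the highest of the three numbers, though its distances to compound 1 and to compound 2 both lie within the scatter. Compound 4 `COc1ccc(-c2cn(-c3cccc(C(=O)/C=C/c4cc(OC)c(OC)c(OC)c4)c3)c(=O)[nH]2)cc1` differs from compound 3 only by 3,4,5-trimethoxyphenyl in place of 4-hydroxy-3-methoxyphenyl on a double-bonded chain carbon bound to a double-bonded chain carbon. Among the measured compounds shown here, no measured step covers this exact change, but compounds 1 and 2 already carry the 3,4,5-trimethoxyphenyl group and sit close to compound 3, so the step of a 1.4-fold lower number from compound 3 to compound 4 (0.13 log units; within the scatter) is expected to stay within the scatter. Compound 4 is estimated at 2500 nM, between 1000 nM and 6000 nM.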

Compound 4, concentration for 50% growth inhibition: 2640 nM
Estimate against measurement, compound 4: 1.1-fold (0.02 log units) below; measured number inside the range.
By their numbers in this assay, from the lowest: compounds 2, 4, 1 and 3 (each within the scatter of the next).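

In this assay, 3,4,5-trimethoxyphenyl in place of 4-hydroxy-3-methoxyphenyl gives a 1.3-fold lower number from compound 3 to compound 4 (0.11 log units; within the scatter), so on this double-bonded chain carbon the read-out does not separate the two groups, even though the hydrogen-bond donor of the hydroxy group is gone. The new compound also links the earlier ones: methoxy in place of hydrogen gives a 1.4-fold higher number from compound 2 to compound 4 (0.15 log units; within the scatter), and methoxy in place of chloro gives a 1.2-fold lower number from compound 1 to compound 4 (0.07 log units; within the scatter), so hydrogen, chloro and methoxy on that aromatic carbon cannot be told apart either. No evidence on the reason for these results is available. Still open, from the compounds shown here alone, is whether an aryl group carrying an amine or a carboxylic acid on this chain carbon would move growth inhibition beyond the scatter.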